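Piperazine for diazepane on the benzamide aryl

The source may report more compounds than this note shows. Statements on the series, on what has been measured and on what is new or still open speak of the compounds shown alone.

Measured so far:
compound 1 `COc1cccc(-c2ccc3c(NC(=O)c4ccc(N5CCN(C)CC5)cc4F)n[nH]c3c2)c1F` — > 1000 nM
compound 2 `COc1ccc(F)c(-c2ccc3c(NC(=O)c4ccc(N5CCCN(C)CC5)cc4)n[nH]c3c2)c1F` — 102 nM

Two compounds carry a number in a functional assay on SNU-16 cells (Homo sapiens) for antiproliferative activity, read by CCK-8 assay, with a stated time of 72 h; on this read-out higher numbers stand for weaker inhibition and lower numbers for stronger inhibition. For compound 1 `COc1cccc(-c2ccc3c(NC(=O)c4ccc(N5CCN(C)CC5)cc4F)n[nH]c3c2)c1F` the result is a limit of the assay, > 1000 nM, not a number. Among the compounds with values here, compound 2 `COc1ccc(F)c(-c2ccc3c(NC(=O)c4ccc(N5CCCN(C)CC5)cc4)n[nH]c3c2)c1F` is the only compound with a measured value, 102 nM in this assay. The other entry, that of compound 1, is a limit, as stated in the limit of > 1000 nM in this assay, at which 1 of the 2 values shown sits. Within the data shown here, no step between two measured compounds can be computed here, so the scatter of the assay is the only yardstick for judging the next change.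

Compound 3 `COc1ccc(F)c(-c2ccc3c(NC(=O)c4ccc(N5C[C@@H](C)N[C@@H](C)C5)cc4)n[nH]c3c2)c1F` keeps the shared core and the fluorinated methoxy-phenyl of compound 2 and changes only the amine on the benzamide ring: 3,5-dimethylpiperazin-1-yl in place of 4-methyl-1,4-diazepan-1-yl on an aromatic carbon. The two groups have the same atoms joined differently; a donor enters with the piperazine.

The expectation for the step from compound 2 to compound 3 in this assay is a 1.5-fold higher number from compound 2 to compound 3 (0.17 log units; within the scatter), i.e. a change that stays within the scatter or slightly weakens inhibition, with a small chance of falling back to a limit. Compound 3 is therefore estimated at 150 nM, between 50 nM and 500 nM.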

Compound 3, half-maximal inhibitory concentration: 582 nM
Estimate against measurement, compound 3: 3.9-fold (0.59 log units) below; the whole stated range lies below it.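

In this assay, within the data shown here, placing 3,5-dimethylpiperazin-1-yl in place of 4-methyl-1,4-diazepan-1-yl on an aromatic carbon, para to a large group, gives a 5.7-fold higher number from compound 2 to compound 3 (0.76 log units; beyond the scatter); this is the first step that can be read, and it shows that this position is sensitive to the choice of cyclic amine. The two groups have the same atoms joined differently, so the step comes without any change in heavy-atom count: a seven-membered ring gives way to a six-membered one, while a hydrogen-bond donor and two defined stereocentres enter, and this single pair cannot separate these changes. Compound 1 remains the only entry whose result is a limit and not a number: the limit of > 1000 nM in this assay, at which 1 of the 3 values shown sits.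

On these data alone, it remains open whether ring size, the ring nitrogen that carries a hydrogen or the two methyl groups accounts for the step, and no measured property here explains it. Unsubstituted piperazin-1-yl and unsubstituted 1,4-diazepan-1-yl on this same scaffold would help to separate these contributions, and morpholine would test whether a second ring nitrogen is needed at all.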